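Moving one trifluoromethyl group: compound 2 to compound 3

The compounds below may be only part of what the source reports. "The series", "measured", "known", "first", "only" and "open" are said of these compounds alone.

Among the compounds with values here, in a functional assay on VCaP cells (Homo sapiens) for antiproliferative activity, read by propidium iodide staining, with a stated time of 96 h (a lower number here means a stronger inhibitor, a higher number a weaker inhibitor), compound 1 (`CC(O)(CSc1ccc(F)cc1)C(=O)Nc1ccc(S(F)(F)(F)(F)F)cc1`) gives 23000 nM and compound 2 (`CC(O)(CSc1ccc(C(F)(F)F)cc1)C(=O)Nc1ccc(S(F)(F)(F)(F)F)cc1`) gives 24800 nM so compound 2 stands level with the only other measured compound, and neither can be called the better inhibitor. Compound 3 (`CC(O)(CSc1cccc(C(F)(F)F)c1)C(=O)Nc1ccc(S(F)(F)(F)(F)F)cc1`) keeps the same atoms as compound 2 but joins them differently, with 3-(trifluoromethyl)phenyl in place of 4-(trifluoromethyl)phenyl on a sulfur. Within the data shown here, only one measured step touches this part of the molecule. Putting trifluoromethyl in place of fluoro on an aromatic carbon gave a 1.1-fold higher number from compound 1 to compound 2 (0.03 log units; within the scatter) and so left the number where it was. Among the measured compounds shown here, that step swaps one group for another and does not move a group to a new place, so it is only a loose guide, and no measured pair tests such a move directly. On this thin evidence, no shift beyond the normal scatter is expected, and the estimated step in this assay is a 1.0-fold lower number from compound 2 to compound 3 (0.01 log units; within the scatter) with real uncertainty around it. For compound 3 the estimated value is 24000 nM with an expected range from 11000 nM to 45000 nM as the likely span of a measurement.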

Compound 3, half-maximal inhibitory concentration: 18800 nM
Compound 3: middle estimate off by 1.3-fold (0.11 log units), on the high side; the range from low to high includes it.
By their numbers in this assay, from the lowest: compounds 3, 1 and 2 (each within the scatter of the next).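

In this assay, shifting the trifluoromethyl group from 4-(trifluoromethyl)phenyl to 3-(trifluoromethyl)phenyl on the sulfur gives a 1.3-fold lower number from compound 2 to compound 3 (0.12 log units; within the scatter), so this direct test of moving a group, rather than swapping it for another, leaves the number where it was. Compared with the 4-fluorophenyl group, the new 3-(trifluoromethyl)phenyl group gives a 1.2-fold lower number from compound 1 to compound 3 (0.09 log units; within the scatter), which means that the three aromatic groups on this sulfur cannot be told apart in this assay, whichever substituent they carry and wherever the trifluoromethyl group sits. No measurement of any property of these groups is available to explain this flat result.

The compounds shown leave open whether a group of a different kind on this aromatic ring, such as an amine or a carboxylic acid, would shift the number beyond the usual scatter. They also leave open what would happen if a longer chain replaced the aromatic ring on the sulfur, or if the shared core were changed elsewhere while this part stayed the same.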